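The source may report more compounds than this note shows. Statements on the series, on what has been measured and on what is new or still open speak of the compounds shown alone.

Measured so far in an ADME assay on RAW264.7 cells (Mus musculus) for cytotoxicity, read by trypan blue exclusion, with a stated time of 48 h; on this read-out higher numbers stand for weaker inhibition of growth and lower numbers for stronger inhibition of growth:
- compound 1 `Cc1ccc(CNCc2cc(C)n(-c3ccc(Cl)cc3)c2C)cc1`: 0.1 ug/mL
- compound 2 `Cc1cc(CNC2CCCCC2)c(C)n1-c1ccc(Cl)cc1`: 10 ug/mL
- compound 3 `Cc1c(CNC2CCCCC2)cc(-c2ccc(Cl)cc2)n1-c1ccc(Cl)cc1`: "not determined" (no result reported)

Compound 3 has no place on the scale, since the entry for compound 3 reads "not determined" (no result reported). It therefore offers no starting number for the step that follows. That step leads to compound 4 `Cc1c(CN2CCN(C)CC2)cc(-c2ccc(Cl)cc2)n1-c1ccc(Cl)cc1`, which is still to be measured in this assay. The change is 4-methylpiperazin-1-yl in place of cyclohexylamino on a saturated chain carbon bound to an aromatic carbon, so 4-methylpiperazin-1-yl takes the place of cyclohexylamino on a saturated chain carbon bound to an aromatic carbon.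

Among the compounds with values here, only one measured step bears on this, and only indirectly. It is a 100-fold higher number from compound 1 to compound 2 (2.00 log units; beyond the scatter), with cyclohexyl in place of 4-methylbenzyl on an amine nitrogen. That step is large, so a change at the amine can move this read-out well beyond the scatter. However, it is a different change from the one at hand, and it says nothing about the direction here. A sizeable step is therefore possible, but no direction can be expected from these data. The nearest number available is that of compound 2 at 10 ug/mL, and the expectation stays close to it, with a wide margin on both sides. For compound 4 the estimated value is 5 ug/mL, with an expected range from 0.8 ug/mL to 30 ug/mL.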

Compound 4, concentration for 50% growth inhibition: 19 ug/mL
Compound 4: middle estimate off by 3.8-fold (0.58 log units), on the low side; the measured number falls inside the stated range.
By their numbers in this assay, from the lowest: compound 1; then compounds 2 and 4 (each within the scatter of the next).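

In this assay compound 4 gives 19 ug/mL while compound 3 has no number on this scale, and the step from compound 3 to compound 4 cannot be read. As far as these compounds go, whether 4-methylpiperazin-1-yl in place of cyclohexylamino moves this read-out, and in which direction, stays open. Nothing available here accounts for the value of compound 4.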